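The source may report more compounds than this note shows. Statements on the series, on what has been measured and on what is new or still open speak of the compounds shown alone.

Working notes on the series. In an assay on HEK293 cells for negative allosteric modulation of metabotropic glutamate receptor 5 (Homo sapiens), read by FLIPR, with a stated time of 1 h (a lower number here means a stronger inhibitor, a higher number a weaker inhibitor), compound 1 `O=C(C1CC12CCC2)N1CCc2nc(C#Cc3ccccc3)sc2C1` gives > 10000 nM, which is a limit of the assay and not a number. Compound 2 `COC1CC(C(=O)N2CCc3nc(C#Cc4ccccc4)sc3C2)C1` gives > 10000 nM in this assay, again a limit. Compound 3 `O=C(C1CCCO1)N1CCc2nc(C#Cc3ccccc3)sc2C1` gives > 10000 nM in this assay, also a limit. All three values therefore sit at the limit of > 10000 nM in this assay, at which 3 of the 3 values shown sit. The steps a step that the two limits leave unreadable from compound 1 to compound 2, a step that the two limits leave unreadable from compound 1 to compound 3 and a step that the two limits leave unreadable from compound 2 to compound 3 cannot be read for size or direction; none tells whether exchanging the group on the carbonyl carbon moves potency at all. Compound 4 `O=C(C1CCCCO1)N1CCc2nc(C#Cc3ccccc3)sc2C1` differs from compound 3 by oxan-2-yl in place of oxolan-2-yl on a carbonyl carbon. Within the data shown here, every value in this assay is a limit, and no measured step gives a readable size for a change of this kind. The expectation for compound 4 in this assay is that it too most likely returns a limit, an estimated 20000 nM with a range from 5000 nM to 100000 nM. The resulting step is expected to be a step that the limit leaves unreadable from compound 3 to compound 4, an estimate that rests on nothing firmer than the three limits already seen.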

Compound 4, half-maximal inhibitory concentration: > 10000 nM
Compound 4 was reported as a limit; the forecaster's own chance of this, stated with the estimate: 85%; the middle value lies beyond the limit too.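

Compound 4 is also a limit, so its steps from compound 1, compound 2 and compound 3 cannot be read for size or direction in this assay: the limit of > 10000 nM in this assay, at which 4 of the 4 values shown sit. The compounds shown leave open whether exchanging the group on the carbonyl carbon moves potency at all.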